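A few compounds are considered here, and "the series" means these few. Any claim that something is new, unique, unknown or untested is made for them only; others in the source may bear on it.

Measured compounds:
compound 1 `CC(=O)Nc1ccc(S(=O)(=O)Oc2ccccc2C(C)C)cc1` — 12000 nM
compound 2 `CC(=O)Nc1ccc(S(=O)(=O)Oc2ccccc2I)cc1` — 17000 nM
compound 3 `CC(C)(C)C(=O)Nc1ccc(S(=O)(=O)Oc2ccccc2I)cc1` — 2600 nM

In a functional assay on HT-1080 cells (Homo sapiens) for antiproliferative activity, read by sulforhodamine B assay, with a stated time of 48 h (on this read-out lower numbers stand for stronger inhibition and higher numbers for weaker inhibition), compound 1 gives the second highest of the three numbers; compound 2 sits within the scatter of it, as a 1.4-fold higher number from compound 1 to compound 2 (0.15 log units; within the scatter) shows, while compound 3 lies beyond the scatter at a lower number. Compound 4 `CC(C)c1ccccc1OS(=O)(=O)c1ccc(NC(=O)CCCl)cc1` differs from compound 1 by chloromethyl in place of hydrogen on a saturated chain carbon bound to a carbonyl carbon. For the measured compounds named here, the only measured step touching the acyl part of the shared core is a 6.5-fold lower number from compound 2 to compound 3 (0.82 log units; beyond the scatter), which enlarged that group and gave a clearly lower number. Compound 4 likewise enlarges the acyl group, though with a different substituent, so a lower number is expected, probably of smaller size. Compound 4 is therefore estimated at 5000 nM (range 2000 nM to 12000 nM), which would mean an expected step of a 2.4-fold lower number from compound 1 to compound 4 (0.38 log units; beyond the scatter).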

Compound 4, half-maximal inhibitory concentration: 6500 nM
Estimate against measurement, compound 4: 1.3-fold (0.11 log units) below; measured number inside the range.
By their numbers in this assay, from the lowest: compound 3; then compounds 4, 1 and 2 (each within the scatter of the next, the first and the last beyond it).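

In this assay, a 1.8-fold lower number from compound 1 to compound 4 (0.27 log units; within the scatter) stays within the scatter, so chloromethyl on this saturated chain carbon bound to a carbonyl carbon leaves no readable change. Enlarging the acyl group therefore does not by itself reproduce a 6.5-fold lower number from compound 2 to compound 3 (0.82 log units; beyond the scatter), although that step belongs to the iodo pair and not to the isopropyl pair. Nothing available explains this result.

Open, going by these compounds, is whether tert-butyl on the core of compound 1 would give a step of similar size. Also open, on these data alone, is whether a longer chain or a terminal amine on the acyl group would move the number beyond the scatter.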